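Working notes on the side chain of compound 3 and compound 4

This account rests on a few compounds, and the source may have more. Where it says the series, first, only, none or still open, it means among the compounds named here.

Measured so far in a functional assay on the whole organism with Rattus norvegicus as the target; a lower number here means that less compound is needed, a higher number that more compound is needed for the effect:
compound 1, `Nc1nc2ccc(I)cc2s1` — in this assay compound 1 reports only a limit, > 10 mg/kg.
compound 2, `Nc1nc2ccc(C(F)(F)C(F)(F)F)cc2s1` — in this assay compound 2 gives 2.5 mg/kg.
compound 3, `N=c1sc2cc(OC(F)(F)F)ccc2n1CC(N)=O` — in this assay compound 3 gives 7 mg/kg.

Of the two numbers recorded, compound 3 stands highest; its nearest neighbour is compound 2, whose number is lower by a margin that lies beyond the usual scatter of repeated runs. Compound 1 contributes (the limit of > 10 mg/kg in this assay, at which 1 of the 3 values shown sits), a limit and not a number. Among the measured compounds shown here, no pair of measured compounds differs in a single place, so no measured step is available.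

Compound 4, `CNCCn1c(=N)sc2cc(OC(F)(F)F)ccc21`, is not yet measured. It differs from compound 3 in one place: (methylamino)methyl in place of carbamoyl on a saturated chain carbon bound to an aromatic nitrogen. The shared core and the trifluoromethoxy group are kept; only the chain on the ring nitrogen changes, the same difference cut one bond further out reading carbamoylmethyl to 2-(methylamino)ethyl.

For the measured compounds named here, with no measured step of this kind to lean on, the expectation for this assay is a change that stays within the scatter, or at most a modest lowering of the number. Compound 4 is therefore expected to give about 5 mg/kg, with a range from 1.5 mg/kg to 15 mg/kg, an estimated step of a 1.4-fold lower number from compound 3 to compound 4 (0.15 log units; within the scatter).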

Compound 4, dose for half-maximal effect: > 10 mg/kg
Compound 4 was reported as a limit; the forecaster's own chance of this, stated with the estimate: 25%; at least 2.0-fold (0.30 log units) between middle value and limit.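

The first step read at this position comes from swapping carbamoyl for (methylamino)methyl on a saturated chain carbon bound to an aromatic nitrogen, and in this assay it reads an at least 1.4-fold higher number from compound 3 to compound 4 (0.15 log units; that floor lies within the scatter). As far as these compounds go, because that step has only a floor, its true size is unknown; the floor itself does not separate the two compounds beyond the scatter, yet the change gives no sign of a lower number, so this chain offers no gain over carbamoylmethyl in this assay. Compound 4 reports a limit and not a number, so it adds a second compound without a usable value: the limit of > 10 mg/kg in this assay, at which 2 of the 4 values shown sit.

What the compounds shown leave open is how far the number of compound 4 lies from that of compound 3, and whether the carbamoyl group itself or the chain as a whole governs the result. A carboxylic acid, a tertiary dimethylamine or a longer chain carrying the carbamoyl group at this same place would help separate these readings, ideally with a measured number and not another limit.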